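Fluoro in place of ethyl on compound 1

A few compounds are considered here, and "the series" means these few. Any claim that something is new, unique, unknown or untested is made for them only; others in the source may bear on it.

Measured so far (a functional assay on A549 cells (Homo sapiens) for antiproliferative activity, read by CCK-8 assay, with a stated time of 72 h; on this read-out higher numbers stand for weaker inhibition and lower numbers for stronger inhibition)
- compound 1 (`CCc1ccc(SCc2ccc(/C=C/C(=O)Nc3ccccc3N)cc2)cc1`) gives 1300 nM 
- compound 2 (`CCc1ccc(SCc2ccc(C(=O)Nc3ccccc3N)cc2)cc1`) gives 3040 nM 

Compound 1 holds the lower of the two numbers, meaning the stronger inhibition, and its gap to compound 2 lies beyond the scatter. Compound 3 (`Nc1ccccc1NC(=O)/C=C/c1ccc(CSc2ccc(F)cc2)cc1`) has not yet been measured. It differs from compound 1 by fluoro in place of ethyl on an aromatic carbon, para to a large group (fluoro in place of ethyl on an aromatic carbon). Among the compounds with values here, no measured pair shows this change, so the data give no direct guide to its size. In this assay no step beyond the scatter is expected, with a slight lean toward a higher number. The expected step is a 1.4-fold higher number from compound 1 to compound 3 (0.14 log units; within the scatter). Within the data shown here, only two numbers stand behind this expectation. For compound 3 the estimated value is 1800 nM, with an expected range from 600 nM to 5000 nM.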

Compound 3, half-maximal inhibitory concentration: 1190 nM
Estimate against measurement, compound 3: 1.5-fold (0.18 log units) above, within the range that was stated.
By their numbers in this assay, from the lowest: compounds 3 and 1 (each within the scatter of the next); then compound 2.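

In this assay, 4-fluorophenyl in place of 4-ethylphenyl gives a 1.1-fold lower number from compound 1 to compound 3 (0.04 log units; within the scatter) and so does not separate the two groups at this position. On this aromatic carbon, para to a large group, a substituent of 1 heavy atom and one of 2 heavy atoms read alike for this pair, which shows that the ethyl group's carbons are not needed to hold the antiproliferative reading of compound 1. No measurement available bears on why the two groups read alike.

Still open, as far as these compounds go, is whether an amine, a carboxylic acid or a longer chain at this position would move the number beyond the scatter. Also open, from the compounds shown here alone, is whether the same exchange of ethyl for fluoro would read alike on the core of compound 2.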